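The source may hold more compounds than are shown below. What is called first, only, known or untested is meant among the compounds shown, and "the series" means these compounds.

Working notes on the series, read in a functional assay on HeLa cells (Homo sapiens) for cytotoxicity, read by sulforhodamine B assay; on this read-out lower numbers stand for stronger inhibition and higher numbers for weaker inhibition. Going by the values given here, compound 1 `COc1ccc(S(=O)(=O)NC(C2=CC(=O)c3c(O)ccc(O)c3C2=O)C(C)C)c(OC)c1` gives 2750 nM, the lowest of the three numbers so far. Compound 2 `CC(C)C(NS(=O)(=O)c1ccc(F)cc1)C1=CC(=O)c2c(O)ccc(O)c2C1=O` gives 6650 nM, and compound 3 `CC(C)C(NS(=O)(=O)c1ccc(Cl)cc1)C1=CC(=O)c2c(O)ccc(O)c2C1=O` gives 8650 nM. Compound 4 `CC(C)C(NS(=O)(=O)c1ccccc1Br)C1=CC(=O)c2c(O)ccc(O)c2C1=O` is not yet measured. Its difference from compound 1 is 2-bromophenyl in place of 2,4-dimethoxyphenyl on a sulfonyl sulfur.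

Two measured steps make a comparable replacement at the same place. These are a 2.4-fold higher number from compound 1 to compound 2 (0.38 log units; beyond the scatter) and a 3.1-fold higher number from compound 1 to compound 3 (0.50 log units; beyond the scatter), both modest and beyond the scatter. The step of a 1.3-fold higher number from compound 2 to compound 3 (0.11 log units; within the scatter) lies within the scatter, so chloro and fluoro are not separated here. Among the compounds with values here, no measured compound carries a 2-bromophenyl group, so this comparison is only approximate. A modest step to a higher number is therefore expected in this assay. The expected step is a 2.5-fold higher number from compound 1 to compound 4 (0.41 log units; beyond the scatter). Compound 4 is estimated at 7000 nM, with an expected range of 3000 nM to 16000 nM.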

Compound 4, half-maximal inhibitory concentration: 8310 nM
For compound 4 the middle estimate is 1.2-fold (0.07 log units) below the measured one; the measured number falls inside the stated range.
By their numbers in this assay, from the lowest: compound 1; then compounds 2, 4 and 3 (each within the scatter of the next).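

In this assay, 2-bromophenyl on the sulfonyl sulfur gives a 3.0-fold higher number from compound 1 to compound 4 (0.48 log units; beyond the scatter) and so joins 4-fluorophenyl and 4-chlorophenyl on the higher side of 2,4-dimethoxyphenyl. A third halogen-bearing phenyl group now reads the same way, and neither a 1.0-fold lower number from compound 3 to compound 4 (0.02 log units; within the scatter) nor a 1.2-fold higher number from compound 2 to compound 4 (0.10 log units; within the scatter) leaves the scatter, so these three groups are not separated at this position. No measurement here bears on the reason for this result.

Whether both methoxy groups of compound 1 are needed for its lower number remains open, as a phenyl group carrying a single methoxy group is not among the compounds shown. Also open, on these data alone, is how an amine or a carboxylic acid on this phenyl ring, or a longer alkyl chain in place of the ring, would read.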